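From Morpholin-4-yl to Diethylamino on a Thiocarbonyl Carbon

This account rests on a few compounds, and the source may have more. Where it says the series, first, only, none or still open, it means among the compounds named here.

Of the compounds shown here, three built on one shared core have been tested in a toxicity assay on HeLa cells (Homo sapiens) for cytotoxicity, read by MTT assay, with a stated time of 24 h; a higher number here means a weaker inhibitor, a lower number a stronger inhibitor. Compound 1 `CCOC(=O)N1CCN(C(=S)SCC(O)Cn2c([N+](=O)[O-])cnc2C)CC1` gives 1610000 nM. Within the data shown here, compound 2 `Cc1ncc([N+](=O)[O-])n1CC(O)CSC(=S)N1CCN(c2ccccc2F)CC1` gives 3240000 nM, and the only measured single-point step, a 2.0-fold higher number from compound 1 to compound 2 (0.30 log units; within the scatter), stays within the scatter. Compound 3 `Cc1ncc([N+](=O)[O-])n1CC(O)CSC(=S)N1CCOCC1` gives 4520000 nM, the highest of the three numbers; compound 3 and compound 2 sit within the scatter of each other, while compound 1 lies beyond it with the lower number.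

Compound 4 `CCN(CC)C(=S)SCC(O)Cn1c([N+](=O)[O-])cnc1C` differs from compound 3 in one place: diethylamino in place of morpholin-4-yl on a thiocarbonyl carbon. Among the measured compounds shown here, no measured step exchanges the group on the thiocarbonyl carbon; the single step on record alters a substituent on a ring nitrogen elsewhere and is itself within the scatter, so it bears on this change only loosely. With nothing in the data pointing to a shift beyond the scatter, the step of a 1.3-fold lower number from compound 3 to compound 4 (0.11 log units; within the scatter) is expected to stay within it. In this assay compound 4 is therefore estimated at 3500000 nM, with a range from 1200000 nM to 10000000 nM.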

Compound 4, half-maximal inhibitory concentration: 2460000 nM
The estimate for compound 4 lay 1.4-fold (0.15 log units) above the measured number, within the range that was stated.
By their numbers in this assay, from the lowest: compounds 1, 4, 2 and 3 (each within the scatter of the next, the first and the last beyond it).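

In this assay, among these compounds, a 1.8-fold lower number from compound 3 to compound 4 (0.26 log units; within the scatter) is the first measured step on the thiocarbonyl carbon, and it stays within the scatter. For this one pair, replacing the six-membered ring of morpholin-4-yl, with its oxygen, by the open diethylamino group leaves the reading indistinguishable, so neither the ring nor its hydrogen-bond acceptor shows a measurable bearing on the number here. No measured evidence is available to explain this result.

Still open, as far as these compounds go, is whether any group on this carbon can move the number beyond the scatter, since a single exchange cannot settle it. Piperidin-1-yl, which keeps the ring without the oxygen, and dipropylamino, a longer chain than diethylamino, would each test separately what this one exchange changes together.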